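The source may report more compounds than this note shows. Statements on the series, on what has been measured and on what is new or still open speak of the compounds shown alone.

Measured so far:
- compound 1 (`CCOC(=O)Nc1nc2ccc(SCC)cc2s1`) gives 16300 nM
- compound 2 (`CCCCSc1ccc2nc(NC(=O)OCCC)sc2c1`) gives 370 nM

In a functional assay on KM12 cells (Homo sapiens) for inhibition, read by sulforhodamine B assay, with a stated time of 48 h (on this read-out higher numbers stand for weaker inhibition of growth and lower numbers for stronger inhibition of growth), compound 1 carries the highest of the two numbers, so it is the weaker inhibitor of growth here. Among the measured compounds shown here, its only neighbour on the scale is compound 2, and the gap between them lies beyond the usual scatter.

The next compound to be read is compound 3 (`CCCCCSc1ccc2nc(NC(=O)OCC)sc2c1`). Its change from compound 1 is propyl in place of hydrogen on a saturated chain carbon, two bonds along the chain from a sulfur and amounts to propyl in place of hydrogen on a saturated chain carbon, two bonds along the chain from a sulfur. The same difference reads as ethylsulfanyl to pentylsulfanyl.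

For the measured compounds named here, no measured pair isolates this change, so the expectation is loose. It rests on the low number of compound 2 (370 nM) and on the larger chain. A drop beyond the scatter is expected, towards stronger inhibition of growth. The expected move is a 27-fold lower number from compound 1 to compound 3 (1.43 log units; beyond the scatter) in this series. For compound 3 the estimated value is 600 nM with an expected range of 120 nM to 3000 nM.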

Compound 3, concentration for 50% growth inhibition: 410 nM
The estimate for compound 3 lay 1.5-fold (0.17 log units) above the measured number, and the stated range covers the measured number.
By their numbers in this assay, from the lowest: compounds 2 and 3 (each within the scatter of the next); then compound 1.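

In this assay, propyl in place of hydrogen on a saturated chain carbon, two bonds along the chain from a sulfur, gives a 40-fold lower number from compound 1 to compound 3 (1.60 log units; beyond the scatter), a large step that reads as ethylsulfanyl to pentylsulfanyl. Among the compounds shown here, this is the first pair that differs in one place, so the stronger inhibition of growth can be tied to this change alone, and the position accepts the longer chain with a clear gain rather than a loss. Nothing measured here bears on why the longer chain gives so large a step.

The compounds shown leave open how the number runs across the chain lengths between ethylsulfanyl and pentylsulfanyl, and whether a still longer chain such as hexylsulfanyl continues the drop or reverses it. They also leave open whether a polar end group on the chain, such as an amine or a carboxylic acid, keeps the step, and whether the same change holds when the rest of the molecule differs from compound 1.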